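From Fluoro to Chloro: Expecting Little Movement

The compounds below may be only part of what the source reports. "The series", "measured", "known", "first", "only" and "open" are said of these compounds alone.

Compound 1 `O=C(/C=C\Nc1ccc(Cl)cc1)c1cn(-c2ccccc2)nc1-c1ccccc1` in a functional assay on U-87MG ATCC cells (Homo sapiens) for antiproliferative activity, read by MTT assay, with a stated time of 48 h; on this read-out higher numbers stand for weaker inhibition and lower numbers for stronger inhibition: 11400 nM
Compound 2 `COc1cc(N/C=C\C(=O)c2cn(-c3ccccc3)nc2-c2ccccc2)cc(OC)c1OC` in this assay: 2350 nM
Compound 3 `COc1cc(N/C=C\C(=O)c2cn(-c3ccccc3)nc2-c2ccc(F)cc2)cc(OC)c1OC` in this assay: 12600 nM

Compound 3 gives the highest number of the three, within the scatter of compound 1 and well above compound 2. Compound 4 `COc1cc(N/C=C\C(=O)c2cn(-c3ccccc3)nc2-c2ccc(Cl)cc2)cc(OC)c1OC` differs from compound 3 by chloro in place of fluoro on an aromatic carbon. Going by the values given here, the only measured step at this position is a 5.4-fold higher number from compound 2 to compound 3 (0.73 log units; beyond the scatter), where fluoro entering raised the number modestly. Among the compounds with values here, no measured step exchanges fluoro for chloro, so the size of this change is not settled by the data. The step from compound 3 to compound 4 is therefore expected to be small, a 1.1-fold lower number from compound 3 to compound 4 (0.02 log units; within the scatter), not clearly beyond the scatter. Compound 4 is estimated at 12000 nM, with a range from 4500 nM to 32000 nM.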

Compound 4, half-maximal inhibitory concentration: 17800 nM
The estimate for compound 4 lay 1.5-fold (0.17 log units) below the measured number; low and high end bracket the measured number.
By their numbers in this assay, from the lowest: compound 2; then compounds 1, 3 and 4 (each within the scatter of the next).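

Chloro in place of fluoro gives a 1.4-fold higher number from compound 3 to compound 4 (0.15 log units; within the scatter) in this assay and so does not separate the two halogens at this position. Chloro in place of hydrogen gives a 7.6-fold higher number from compound 2 to compound 4 (0.88 log units; beyond the scatter) and shows that the rise seen with fluoro also appears with a second halogen. No measurement at hand explains this rise. As far as these compounds go, whether an amine or a hydroxyl group on this ring would also raise the number, or leave it near that of compound 2, stays open.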